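The source may hold more compounds than are shown below. What is called first, only, known or untested is meant among the compounds shown, and "the series" means these compounds.

Three measured compounds frame the series. In a functional assay on DU-145 cells (Homo sapiens) for inhibition, read by trypan blue exclusion, with a stated time of 96 h (on this read-out lower numbers stand for stronger inhibition of growth and higher numbers for weaker inhibition of growth), compound 1 `O=C(/C(=C\c1ccc(O)cc1O)SCc1cccc(Cl)c1)c1ccc(Br)cc1` gives 50000 nM, compound 3 `O=C(/C(=C/c1ccc(Cl)cc1)Cc1c[nH]c2ccccc12)c1ccc(Cl)cc1Cl` gives 10000 nM, and compound 2 `O=C(/C(=C\c1ccc(I)cc1)S(=O)(=O)c1ccc(Br)cc1)c1ccc(Br)cc1` gives 1000 nM, the lowest of the three numbers; its gaps to compound 3 and to compound 1 both lie beyond the scatter, so compound 2 is the strongest inhibitor of growth among the measured set. Compound 4 `O=C(/C(=C\c1ccc(F)cc1)S(=O)(=O)c1ccc(Br)cc1)c1ccc(Br)cc1` is not yet measured. It differs from compound 2 only as follows: fluoro in place of iodo on an aromatic carbon. Going by the values given here, no measured pair shows this change alone, so its size is not known from the series. The step from compound 2 to compound 4 in this assay is expected to be small, towards weaker inhibition, at about a 2.0-fold higher number from compound 2 to compound 4 (0.30 log units; within the scatter). For compound 4 the expected result in this assay is 2000 nM, within 700 nM to 6000 nM.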

Compound 4, concentration for 50% growth inhibition: 4000 nM
Compound 4: middle estimate off by 2.0-fold (0.30 log units), on the low side, and the stated range covers the measured number.
By their numbers in this assay, from the lowest: compound 2; then compound 4; then compound 3; then compound 1.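

In this assay, going by these compounds alone, replacing 4-iodophenyl with 4-fluorophenyl gives a 4.0-fold higher number from compound 2 to compound 4 (0.60 log units; beyond the scatter), the first single-place step. The halogen on this aromatic carbon, para to a large group, therefore affects inhibition of growth, with iodo ahead of fluoro in this one pair. Nothing measured here accounts for the size or direction of this step.

Going by these compounds, whether chloro or bromo at this carbon would fall between iodo and fluoro remains open, as does the result with an amine or a methoxy group there. A single pair also cannot show whether the same change acts alike on other cores.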